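Swapping a chlorobenzyl for a dimethoxybenzyl group

The source may hold more compounds than are shown below. What is called first, only, known or untested is meant among the compounds shown, and "the series" means these compounds.

Compound 1 `O=C(NCc1cn(Cc2ccc(Cl)cc2)nn1)c1cn(-c2ccccc2)nc1-c1ccccc1` gives 8700 nM in a functional assay on MIA PaCa-2 cells (Homo sapiens) for antiproliferative activity, read by sulforhodamine B assay, with a stated time of 48 h; a lower number here means a stronger inhibitor of growth, a higher number a weaker inhibitor of growth.
Compound 2 `COc1cc(Cn2cc(CNC(=O)c3cn(-c4ccccc4)nc3-c3ccc(F)cc3)nn2)cc(OC)c1` gives 190 nM in this assay.
Compound 3 `COc1ccc(-c2nn(-c3ccccc3)cc2C(=O)NCc2cn(Cc3ccc(Cl)cc3)nn2)cc1` gives 26300 nM in this assay.

Compound 3 stands at the weak end of these three compounds: its number is the highest, with compound 1 nearest and compound 2 far below. Among the measured compounds shown here, the only measured single-point step, a 3.0-fold higher number from compound 1 to compound 3 (0.48 log units; beyond the scatter), shows that the methoxy on the aryl ring of the core weakened growth inhibition modestly.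

Compound 4 `COc1ccc(-c2nn(-c3ccccc3)cc2C(=O)NCc2cn(Cc3cc(OC)cc(OC)c3)nn2)cc1` arises from compound 3 through (3,5-dimethoxyphenyl in place of 4-chlorophenyl on a saturated chain carbon bound to an aromatic nitrogen). For the measured compounds named here, no measured step covers exactly this exchange. The closest guidance comes from comparing compound 1 and compound 2, which differ in this benzyl group and also in a fluorine on the aryl ring of the core. Compound 2, carrying the dimethoxybenzyl group, gives 190 nM, whereas compound 1, carrying the chlorobenzyl group, gives 8700 nM. That gap is large and beyond the scatter, so a large move toward stronger inhibition is expected in this assay for compound 4, amounting to a 33-fold lower number from compound 3 to compound 4 (1.52 log units; beyond the scatter). Compound 4 is therefore estimated at 800 nM, with a range from 200 nM to 5000 nM.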

Compound 4, concentration for 50% growth inhibition: 5800 nM
For compound 4 the middle estimate is 7.3-fold (0.86 log units) below the measured one; measured number outside the range, above it.
By their numbers in this assay, from the lowest: compound 2; then compounds 4 and 1 (each within the scatter of the next); then compound 3.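

In this assay, among the compounds shown here, the benzyl exchange can now be read on its own for the first time, with the rest of the molecule held fixed: 3,5-dimethoxyphenyl in place of 4-chlorophenyl gives a 4.5-fold lower number from compound 3 to compound 4 (0.66 log units; beyond the scatter), a real but modest gain. With the 3,5-dimethoxybenzyl group held constant, methoxy in place of fluoro on the aromatic carbon of the core gives a 31-fold higher number from compound 2 to compound 4 (1.48 log units; beyond the scatter), a large loss and the bigger of these two single changes, so the group on that core ring weighs more here than the benzyl exchange does. No measurement shown explains either step.

As far as these compounds go, the benzyl exchange is read only with methoxy on the core ring, so its size with fluoro or hydrogen at that carbon remains open. Also open, from the compounds shown here alone, is how far growth inhibition would move with other groups on that aromatic carbon, such as a hydroxyl, a nitrile or a dimethylamino group, and whether any of them would give a lower number than the fluoro of compound 2.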